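This account rests on a few compounds, and the source may have more. Where it says the series, first, only, none or still open, it means among the compounds named here.

Notes on the series built on the shared core of compound 1 `O=C(Nc1ccccc1)Nc1nnc(Sc2ncnc3scc(-c4ccncc4)c23)s1`. In a functional assay on T47D cells (Homo sapiens) for antiproliferative activity, read by MTT assay, with a stated time of 48 h (a higher number here means a weaker inhibitor, a lower number a stronger inhibitor), compound 1 gives 23300 nM. Compound 2 `COc1ccc(NC(=O)Nc2nnc(Sc3ncnc4scc(-c5ccncc5)c34)s2)cc1` carries a methoxy on the phenyl of the urea. In this assay compound 2 returns only a limit, > 100000 nM, so no number is known for it: this is the limit of > 100000 nM in this assay, at which 1 of the 2 values shown sits. Compound 2 thus stands at the weak end of what has been measured, its true value open upward. Compound 3 `O=C(Nc1ccc(F)cc1)Nc1nnc(Sc2ncnc3scc(-c4ccncc4)c23)s1` differs from compound 2 by fluoro in place of methoxy on an aromatic carbon. For the measured compounds named here, the one measured step at this position is an at least 4.2-fold higher number from compound 1 to compound 2 (0.63 log units; beyond the scatter), in which the methoxy cost potency relative to the unsubstituted phenyl of compound 1. Fluoro occupies the same position, so compound 3 is expected to fall between compound 1 and the limit of compound 2, with some chance that only a limit is reported again. The estimate for compound 3 in this assay is 40000 nM, ranging from 15000 nM to 150000 nM. That expected outcome corresponds to an at least 2.5-fold lower number from compound 2 to compound 3 (0.39 log units; beyond the scatter).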

Compound 3, half-maximal inhibitory concentration: 18900 nM
Compound 3: the middle estimate sits 2.1-fold (0.33 log units) above what was measured; the range from low to high includes it.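

In this assay, fluoro in place of methoxy gives an at least 5.2-fold lower number from compound 2 to compound 3 (0.72 log units; beyond the scatter), so this position on the phenyl of the urea does not lose potency with every substituent. Fluoro in place of hydrogen gives a 1.2-fold lower number from compound 1 to compound 3 (0.09 log units; within the scatter), so among the compounds shown the loss belongs to methoxy and not to substitution as such. The full size of the methoxy-to-fluoro step stays unknown because compound 2 is held only by a limit: the limit of > 100000 nM in this assay, at which 1 of the 3 values shown sits.

As far as these compounds go, it remains open whether an amine, a carboxylic acid or a longer chain such as ethoxy at this place would track fluoro or methoxy. Also open, from the compounds shown here alone, is whether any group here gives a number clearly lower than that of compound 1.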